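The compounds below may be only part of what the source reports. "The series", "measured", "known", "first", "only" and "open" are said of these compounds alone.

Compound 1 `Cc1ccc(S/C(=C/c2c[nH]c3ccccc23)C(=O)c2ccc(Br)cc2)cc1`: 10000 nM
Compound 2 `O=C(/C(=C\c1c(O)cc(O)cc1O)S(=O)(=O)c1ccccc1Br)c1ccc(Br)cc1`: 50000 nM

In a functional assay on DU-145 cells (Homo sapiens) for inhibition, read by trypan blue exclusion, with a stated time of 96 h (a higher number here means a weaker inhibitor of growth, a lower number a stronger inhibitor of growth), compound 2 gives 50000 nM, the highest of the two numbers; compound 1 gives 10000 nM, and the gap between them is beyond the usual scatter. Compound 3 `Cc1ccc(S/C(=C/c2c(O)cc(O)cc2O)C(=O)c2ccc(Br)cc2)cc1` has not been measured. It differs from compound 2 by (4-methylphenyl)sulfanyl in place of (2-bromophenyl)sulfonyl on a double-bonded chain carbon bound to a carbonyl carbon and a double-bonded chain carbon. The entering group is the same one carried by compound 1, which gives 10000 nM in this assay. The step from compound 2 to compound 3 is therefore expected to be a moderate drop, a 3.3-fold lower number from compound 2 to compound 3 (0.52 log units; beyond the scatter). Compound 3 is estimated at 15000 nM, with a likely range from 4000 nM to 50000 nM.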

Compound 3, concentration for 50% growth inhibition: > 100000 nM
Compound 3: a limit, no number; the forecaster's own chance of this, stated with the estimate: 10%; middle value at least 6.6-fold (0.82 log units) away from the limit.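

In this assay, compound 3 gives a limit and not a number: the limit of > 100000 nM in this assay, at which 1 of the 3 values shown sits.

With the 2,4,6-trihydroxyphenyl group kept, the sulfur-group swap shows no gain, with an at least 2.0-fold higher number from compound 2 to compound 3 (0.30 log units; that floor lies within the scatter), so the group carried by compound 1 does not give compound 3 a stronger reading than compound 2. With the (4-methylphenyl)sulfanyl group kept, the aromatic group on the chain matters, with an at least 10-fold higher number from compound 1 to compound 3 (1.00 log units; beyond the scatter).

Still open, as far as these compounds go, is how far compound 3 lies past its limit, and whether an amine in place of the sulfur group would retain growth inhibition.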